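The source may hold more compounds than are shown below. What is called first, only, known or untested is meant among the compounds shown, and "the series" means these compounds.

Measured compounds:
compound 1, `COc1cc(OC)cc(-c2cc3ccccc3c(-c3cccc(N)c3)n2)c1`, gives 980 nM in a functional assay on T47D cells (Homo sapiens) for cytotoxicity, read by CCK-8 assay and cell counting, with a stated time of 72 h; on this read-out lower numbers stand for stronger inhibition and higher numbers for weaker inhibition
compound 2, `COc1cc(OC)cc(-c2cc3ccccc3c(-c3ccc(O)cc3)n2)c1`, gives 780 nM in this assay
compound 3, `COc1ccc(-c2cc3cc(C)ccc3c(-c3cccc(N)c3)n2)cc1OC`, gives 450 nM in this assay

Compound 1 and compound 2 share a core and differ only in one group: 4-hydroxyphenyl in place of 3-aminophenyl on an aromatic carbon. That change gave a 1.3-fold lower number from compound 1 to compound 2 (0.10 log units; within the scatter). Compound 3 carries a different core; the difference between the core of compound 1 and the core of compound 3 is not broken down here. Compound 4, `COc1ccc(-c2cc3cc(C)ccc3c(-c3ccc(O)cc3)n2)cc1OC`, has not yet been measured. It differs from compound 3 by 4-hydroxyphenyl in place of 3-aminophenyl on an aromatic carbon, which is the same change as that from compound 1 to compound 2, at a place described in the same words. Because a 1.3-fold lower number from compound 1 to compound 2 (0.10 log units; within the scatter) lay within the scatter, a step of like size is expected here, a 1.3-fold lower number from compound 3 to compound 4 (0.11 log units; within the scatter). Compound 4 is therefore estimated at 350 nM, most likely between 170 nM and 750 nM.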

Compound 4, half-maximal inhibitory concentration: 4420 nM
Compound 4: the middle estimate sits 13-fold (1.10 log units) below what was measured, outside the stated range (above it).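

In this assay, putting 4-hydroxyphenyl in place of 3-aminophenyl gave a 9.8-fold higher number from compound 3 to compound 4 (0.99 log units; beyond the scatter). The same change therefore did not carry over from one core to the other, and the two steps differ clearly: the same change on two cores in this assay, a 1.3-fold lower number (0.10 log units; within the scatter) from compound 1 to compound 2 and a 9.8-fold higher number (0.99 log units; beyond the scatter) from compound 3 to compound 4, 12-fold (1.09 log units) apart, beyond the scatter of two such steps. This shows that the result on one core did not predict the result on the other, but it does not show which difference between the cores is responsible, or how the change would behave on a third core.

The compounds shown leave open how a plain phenyl or a phenyl bearing a carboxylic acid would behave at this place on either core. Such compounds would show whether the sensitivity of the core of compound 3 extends beyond these two groups.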